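The compounds below may be only part of what the source reports. "The series", "measured", "known", "first", "only" and "open" are said of these compounds alone.

Measured so far:
compound 1 `c1ccc2c(-c3cn4ccnc4c(-c4ccc5ncn(C6CCCCC6)c5c4)n3)cccc2c1` — 22.9%
compound 2 `COc1ccccc1-c1cn2ccnc2c(-c2ccc3ncn(C4CCCCC4)c3c2)n1` — 35.9%

In a functional assay on RPMI-8226 cells (Homo sapiens) for inhibition, read by sulforhodamine B assay, with a stated time of 48 h, tested at 10 uM (a lower number here means less inhibition, a higher number more inhibition at the concentration tested (going by the name of the read-out)), compound 1 gives 22.9%; compound 2 gives 35.9%. Among the compounds with values here, compound 2 therefore stands highest of the two numbers so far, with compound 1 as its only neighbour, and the step of a number 13 percentage points higher from compound 1 to compound 2 (beyond the scatter) is beyond the scatter.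

Compound 3 `c1csc(-c2cn3ccnc3c(-c3ccc4ncn(C5CCCCC5)c4c3)n2)c1` is the next member of the series. It differs from compound 2 in one place: thiophen-2-yl in place of 2-methoxyphenyl on an aromatic carbon. Within the data shown here, the only measured step that bears on this change is a number 13 percentage points higher from compound 1 to compound 2 (beyond the scatter), since that step too exchanges the group on an aromatic carbon of the shared core. It shows that a replacement at this aromatic carbon moves the number in this assay by a modest amount, but with two compounds there is nothing to tell whether a thiophen-2-yl will move it up or down from compound 2. For compound 3 the step of a number 5.9 percentage points lower from compound 2 to compound 3 (within the scatter) is therefore expected to be small and of uncertain direction, most likely within the scatter. Compound 3 is estimated to give 30% in this assay, in the range 10% to 50%.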

Compound 3, a percentage reported as inhibition, at one concentration (the size of the read-out at that concentration, not a potency): 52.3%
Compound 3: middle estimate off by 22.3 percentage points, on the low side; measured number above the stated range.
By their numbers in this assay, from the lowest: compound 1; then compound 2; then compound 3.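

In this assay, the exchange at this aromatic carbon gives a number 16.4 percentage points higher from compound 2 to compound 3 (beyond the scatter), so the position can carry a five-membered aromatic ring with a sulfur atom as well as the larger aromatic groups, and the number rises with that exchange. Measured against the naphthalen-1-yl group, the same thiophen-2-yl gives a number 29.4 percentage points higher from compound 1 to compound 3 (beyond the scatter), so among these three compounds, which share the rest of the structure, the group at this carbon alone spans a range well beyond the scatter, with thiophen-2-yl at the top and naphthalen-1-yl at the bottom. No measurement on these compounds offers an explanation for the order of the three groups.

Open, on these data alone, is whether the rise belongs to the sulfur atom, to the five-membered ring or to the point of attachment, a question that furan-2-yl, with oxygen in place of sulfur, and thiophen-3-yl would help to separate. Also open, as far as these compounds go, is how a substituent on the thiophen-2-yl ring, such as an amine or a carboxylic acid, would shift the number at this single concentration.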